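Pyrrolidinylmethyl extension on the amide aryl ring of compound 3

The source may hold more compounds than are shown below. What is called first, only, known or untested is meant among the compounds shown, and "the series" means these compounds.

Compound 1, `Cc1ccc(Nc2ncc3c(n2)N(Cc2ccccc2)C(=O)N(c2cc(NC(=O)c4ccc(C)c(C(F)(F)F)c4)ccc2C)C3)cn1`: in an ADME assay on BaF3 cells (Mus musculus) for inhibition, read by CellTiter-Glo, with a stated time of 72 h (a higher number here means a weaker inhibitor of growth, a lower number a stronger inhibitor of growth), compound 1 gives > 5000 nM, which is a limit of the assay and not a number.
Compound 2, `CCN1CCN(c2ccc(Nc3ncc4c(n3)N(C)C(=O)N(c3cc(NC(=O)c5cccc(C(F)(F)F)c5)ccc3C)C4)cc2)CC1`: in this assay compound 2 gives 559 nM.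
Compound 3, `Cc1ccc(NC(=O)c2cccc(C(F)(F)F)c2)cc1N1Cc2cnc(Nc3cnn(C)c3)nc2N(C)C1=O`: in this assay compound 3 gives 352 nM.

Compound 3 holds the lower of the two numbers, but its value and that of compound 2 lie within the scatter of each other, so no order between them is claimed. Compound 1 sits at the limit of > 5000 nM in this assay, at which 1 of the 3 values shown sits.

Compound 4, `Cc1ccc(NC(=O)c2ccc(CN3CCC(N(C)C)C3)c(C(F)(F)F)c2)cc1N1Cc2cnc(Nc3cnn(C)c3)nc2N(C)C1=O`, differs from compound 3 in one place: (3-(dimethylamino)pyrrolidin-1-yl)methyl in place of hydrogen on an aromatic carbon. Among the measured compounds shown here, no measured step bears on a change of this kind, so there is little to lean on. The expected step, a 1.3-fold lower number from compound 3 to compound 4 (0.10 log units; within the scatter), is small, within the scatter, with no clear direction. Compound 4 is expected to give 280 nM in this assay, with a range from 70 nM to 1100 nM.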

Compound 4, concentration for 50% growth inhibition: 414 nM
Compound 4: the middle estimate sits 1.5-fold (0.17 log units) below what was measured; low and high end bracket the measured number.
By their numbers in this assay, from the lowest: compounds 3, 4 and 2 (each within the scatter of the next). At a limit, above all of these: compound 1.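

The aromatic carbon ortho to the trifluoromethyl group and para to a large group takes (3-(dimethylamino)pyrrolidin-1-yl)methyl, 9 heavy atoms in place of hydrogen, with a 1.2-fold higher number from compound 3 to compound 4 (0.07 log units; within the scatter) in this assay. The group's size therefore does not separate compound 4 from compound 3 in this read-out. Nothing measured here gives a cause for this step.

Open, as far as these compounds go, is what a morpholin-4-ylmethyl group or a carboxylic acid would give at this place. Also open, from the compounds shown here alone, is what the pyrrolidine gives without its dimethylamino group.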